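Swapping an Ester for a Diol on a Shared Core

The compounds below may be only part of what the source reports. "The series", "measured", "known", "first", "only" and "open" are said of these compounds alone.

compound 1 `CCCc1nc(C)c2cnn(CC(O)CO)c(=O)n12`: > 48000 nM
compound 2 `CCCc1nc(C)c2c(C)nn(CC(=O)OCC)c(=O)n12`: > 48000 nM

In a functional assay for inhibition, with Homo sapiens as the target (a lower number here means a stronger inhibitor, a higher number a weaker inhibitor), compound 1 gives > 48000 nM, which is a limit of the assay and not a number. In this assay compound 2 likewise gives > 48000 nM, again a limit rather than a number. Both values therefore sit at the limit of > 48000 nM in this assay, at which 2 of the 2 values shown sit, so compound 2 stands at the limit itself, and nothing finer can be said of its place. Compound 3 `CCCc1nc(C)c2c(C)nn(CC(O)CO)c(=O)n12` is not yet measured. It keeps the core of compound 2 and differs only in 1,2-dihydroxyethyl in place of ethoxycarbonyl on a saturated chain carbon bound to an aromatic nitrogen. Among the compounds with values here, the group that enters is the one carried by compound 1, and the core it joins is the one of compound 2, and each of those two compounds shows only a limit. Compound 3 is expected to give 70000 nM, between 20000 nM and 300000 nM, most likely reported again as a limit. The expected step that the limit leaves unreadable from compound 2 to compound 3 thus amounts to no change beyond the scatter.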

Compound 3, half-maximal inhibitory concentration: > 48000 nM
Compound 3: a limit, no number; the forecaster's own chance of this, stated with the estimate: 85%; the middle value is on the limit's open side.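

In this assay compound 3 gives > 48000 nM as a limit of the assay and not a number. The steps to compound 3 from compound 1 and compound 2 therefore cannot be read: the limit of > 48000 nM in this assay, at which 3 of the 3 values shown sit.

The compounds shown leave open whether either change alters inhibition, and how strong any of the three compounds is.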